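The compounds below may be only part of what the source reports. "The series", "measured", "known", "first", "only" and "open" are said of these compounds alone.

Measured compounds in a functional assay on HepG2 cells (Homo sapiens) for cytotoxicity, read by MTT assay, with a stated time of 48 h; on this read-out lower numbers stand for stronger inhibition and higher numbers for weaker inhibition:
- compound 1 `O=C(Nc1ccc(S(=O)(=O)NC2CCCCC2)cc1)C1C(C(=O)O)[C@H]2CC[C@@H]1O2`; in this assay compound 1 gives 22500 nM
- compound 2 `O=C(Nc1ccc(S(=O)(=O)N2CCOCC2)cc1)C1C(C(=O)O)[C@H]2CC[C@@H]1O2`; compound 2 gives 19300 nM
- compound 3 `O=C(Nc1ccc(S(=O)(=O)NC2CCCC2)cc1)C1C(C(=O)O)[C@H]2CC[C@@H]1O2`; compound 3 gives 22300 nM

Compound 3 stands second highest of the three numbers, but the three lie within the scatter of one another: a 1.0-fold lower number from compound 1 to compound 3 (0.00 log units; within the scatter) and a 1.2-fold higher number from compound 2 to compound 3 (0.06 log units; within the scatter). Nothing in this set separates the three sulfonyl substituents on the read-out.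

Compound 4 `O=C(Nc1ccc(S(=O)(=O)NC2CC2)cc1)C1C(C(=O)O)[C@H]2CC[C@@H]1O2` keeps the shared core and the sulfonamide and differs from compound 3 in one place: cyclopropyl in place of cyclopentyl on a sulfonamide nitrogen. The step that bears most directly on it is a 1.0-fold lower number from compound 1 to compound 3 (0.00 log units; within the scatter), which already swaps one carbocycle for a smaller one on the sulfonamide nitrogen without a change beyond the scatter. The step of a 1.2-fold higher number from compound 2 to compound 3 (0.06 log units; within the scatter), exchanging a cyclic amine on the sulfonyl sulfur for a cycloalkylamino group, is likewise within the scatter. On these two steps a further reduction of the ring on the sulfonamide nitrogen is not expected to move the number beyond the scatter in either direction.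

Compound 4 is therefore estimated at 22000 nM, with a range of 11000 nM to 45000 nM. The step of a 1.0-fold lower number from compound 3 to compound 4 (0.01 log units; within the scatter) is expected to stay within the scatter.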

Compound 4, half-maximal inhibitory concentration: 26200 nM
Beside the measured number, compound 4's estimate is 1.2-fold (0.08 log units) below it; measured number inside the range.
By their numbers in this assay, from the lowest: compounds 2, 3, 1 and 4 (each within the scatter of the next).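

In this assay, taking the carbocycle on the sulfonamide nitrogen down to cyclopropyl leaves the number within the scatter, both against cyclopentyl (a 1.2-fold higher number from compound 3 to compound 4 (0.07 log units; within the scatter)) and against cyclohexyl (a 1.2-fold higher number from compound 1 to compound 4 (0.07 log units; within the scatter)), so the read-out does not tell these three ring sizes apart at this position. Cyclopropylamino in place of morpholin-4-yl on a sulfonyl sulfur gives the largest step in the set so far, yet that step also stays within the scatter (a 1.4-fold higher number from compound 2 to compound 4 (0.13 log units; within the scatter)), and all four sulfonyl substituents remain unseparated. No accompanying data bear on this result, so the flat read-out can be described here but not explained.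

As far as these compounds go, whether any group on the sulfonamide nitrogen can move the number beyond the scatter remains open, for example a phenyl ring, a longer butyl chain or an aminoethyl chain. The carboxylic acid is common to all four compounds, so what an ester or a primary amide at that place would do to the number cannot be read from them.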